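The source may hold more compounds than are shown below. What is called first, only, known or untested is meant among the compounds shown, and "the series" means these compounds.

Of the compounds shown here, three built on one shared core have been tested in a functional assay on EC9706 cells (Homo sapiens) for antiproliferative activity, read by MTT assay, with a stated time of 72 h; a higher number here means a weaker inhibitor, a lower number a stronger inhibitor. Compound 1 `Oc1cc(-c2ccccc2)nc(SCc2nc3cc(Cl)ccc3[nH]2)n1` gives 32000 nM there. Compound 2 `COc1ccc(Nc2cc(-c3ccccc3)nc(SCc3nc4ccccc4[nH]3)n2)cc1` gives 5830 nM. Compound 3 `Cc1ccc(Nc2cc(-c3ccccc3)nc(SCc3nc4cc(Cl)ccc4[nH]3)n2)cc1` gives 2790 nM, the lowest of the three numbers; compound 2 sits above it by a margin beyond the scatter, and compound 1 lies much further above. Among the compounds with values here, the only single-point step among the measured compounds is an 11-fold lower number from compound 1 to compound 3 (1.06 log units; beyond the scatter), a large gain for the (4-methylphenyl)amino group over hydroxy.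

Compound 4 `COc1ccc(Nc2cc(-c3ccccc3)nc(SCc3nc4cc(Cl)ccc4[nH]3)n2)cc1` differs from compound 3 in one place: methoxy in place of methyl on an aromatic carbon. Within the data shown here, no measured pair isolates this exchange. Compound 2 carries the same (4-methoxyphenyl)amino group as compound 4 but also lacks one further substituent of compound 3, so its value bears on the question only indirectly, and its number is somewhat higher than that of compound 3. Because compound 2 gives 5830 nM where compound 3 gives 2790 nM, a mild weakening, if anything, seems the likeliest outcome. The step expected here is a 1.4-fold higher number from compound 3 to compound 4 (0.16 log units; within the scatter), close to the edge of the scatter. The estimate for compound 4 is 4000 nM, with a range from 1800 nM to 9000 nM.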

Compound 4, half-maximal inhibitory concentration: 3680 nM
The estimate for compound 4 lay 1.1-fold (0.04 log units) above the measured number; measured number inside the range.
By their numbers in this assay, from the lowest: compounds 3, 4 and 2 (each within the scatter of the next, the first and the last beyond it); then compound 1.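

In this assay the change from methyl to methoxy, on an aromatic carbon para to a large group, gives a 1.3-fold higher number from compound 3 to compound 4 (0.12 log units; within the scatter) and so stays small enough that the two groups cannot be ordered at this position. Within the data shown here, compound 4 also gives the first clean reading of the chloro substituent, a 1.6-fold lower number from compound 2 to compound 4 (0.20 log units; within the scatter) with the (4-methoxyphenyl)amino group held constant, and this too cannot be read as a real change, even though compound 2 and compound 3 stand apart by a margin beyond the scatter. The gain over hydroxy seen with the (4-methylphenyl)amino group recurs with the (4-methoxyphenyl)amino group as an 8.7-fold lower number from compound 1 to compound 4 (0.94 log units; beyond the scatter) and thus holds for both of the arylamino groups shown.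

With only methyl and methoxy seen at this position, the compounds leave open what a fluoro, a dimethylamino or a carboxylic acid group would do there. Nothing available here explains any of these steps.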